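Returning to a pyrazole on the aniline nitrogen

The source may hold more compounds than are shown below. What is called first, only, known or untested is meant among the compounds shown, and "the series" means these compounds.

Of the compounds shown here, two from this series have been measured in a functional assay on HCT-116 cells (Homo sapiens) for antiproliferative activity, read by sulforhodamine B assay, with a stated time of 72 h; a higher number here means a weaker inhibitor, a lower number a stronger inhibitor. Compound 1 `COc1ncc(-c2ccc3ncnc(Nc4cnn(CCCO)c4)c3c2)cc1NS(C)(=O)=O` gives 1420 nM. For the measured compounds named here, compound 2 `COc1ncc(-c2ccc3ncnc(Nc4ccc(OCCO)cc4)c3c2)cc1NS(C)(=O)=O` gives 4860 nM, the highest of the two numbers, with compound 1 as its only neighbour, a 3.4-fold higher number from compound 1 to compound 2 (0.53 log units; beyond the scatter). Compound 3 `COC(=O)CCn1cc(Nc2ncnc3ccc(-c4cnc(OC)c(NS(C)(=O)=O)c4)cc23)cn1` is not yet measured; it differs from compound 2 in one place: 1-(2-(methoxycarbonyl)ethyl)-1H-pyrazol-4-yl in place of 4-(2-hydroxyethoxy)phenyl on a nitrogen on an aromatic ring. Going by the values given here, the only step that bears on this change is the one between compound 1 and compound 2, where a pyrazole attached at the same nitrogen stood against the phenyl group with the hydroxyethoxy chain, a 3.4-fold higher number from compound 1 to compound 2 (0.53 log units; beyond the scatter). From the compounds shown here alone, since compound 3 carries a pyrazole again, a step back toward the number of compound 1 is expected, a 2.7-fold lower number from compound 2 to compound 3 (0.43 log units; beyond the scatter), though the chain on the pyrazole is different and its own effect is unknown. The estimate for compound 3 in this assay is therefore 1800 nM, with a range from 600 nM to 5500 nM.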

Compound 3, half-maximal inhibitory concentration: 970 nM
Beside the measured number, compound 3's estimate is 1.9-fold (0.27 log units) above it; measured number inside the range.
By their numbers in this assay, from the lowest: compounds 3 and 1 (each within the scatter of the next); then compound 2.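

In this assay, the pyrazole on the aniline nitrogen again goes with the lower number, now with a different chain: 1-(2-(methoxycarbonyl)ethyl)-1H-pyrazol-4-yl in place of 4-(2-hydroxyethoxy)phenyl gives a 5.0-fold lower number from compound 2 to compound 3 (0.70 log units; beyond the scatter). The end of the chain on the pyrazole made no clear difference, since methoxycarbonyl in place of hydroxymethyl gives a 1.5-fold lower number from compound 1 to compound 3 (0.17 log units; within the scatter), so a free hydroxyl there is not needed to keep this level of activity. No measurement shown here explains either result.

From the compounds shown here alone, the step away from compound 2 changes both the ring and its chain at once, so the share of each remains unknown. Going by these compounds, how a carboxylic acid or an amine at the end of the chain, or a longer chain on the pyrazole, would compare also remains open.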